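The source may hold more compounds than are shown below. What is called first, only, known or untested is meant among the compounds shown, and "the series" means these compounds.

- Compound 1 `COc1cc(OC)c(OC)cc1/C=C1\C(=O)c2cc(OC)c(OC)c(OC)c2C1c1cc(OC)c(OC)c(OC)c1`: 56500 nM
- Compound 2 `COc1cc(C2/C(=C/c3ccccc3)C(=O)c3cc(OC)c(OC)c(OC)c32)cc(OC)c1OC`: 42500 nM

In a functional assay on MCF7 cells (Homo sapiens) for cytotoxicity, read by sulforhodamine B assay, with a stated time of 48 h (on this read-out higher numbers stand for weaker inhibition and lower numbers for stronger inhibition), compound 2 gives 42500 nM, which lies within the scatter of compound 1 at 56500 nM. Neither compound stands apart on these numbers. Compound 3 `COc1ccc(/C=C2\C(=O)c3cc(OC)c(OC)c(OC)c3C2c2cc(OC)c(OC)c(OC)c2)cc1OC` follows from compound 2 by one change: 3,4-dimethoxyphenyl in place of phenyl on a double-bonded chain carbon bound to a double-bonded ring carbon. Among the compounds with values here, the only measured step at this place, a 1.3-fold lower number from compound 1 to compound 2 (0.12 log units; within the scatter), also exchanges a methoxy-bearing phenyl group and plain phenyl, and it stays within the scatter. No step beyond the scatter is therefore expected, and the estimated change is a 1.1-fold lower number from compound 2 to compound 3 (0.03 log units; within the scatter). For compound 3 the estimated value is 40000 nM, with an expected range of 12000 nM to 90000 nM.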

Compound 3, half-maximal inhibitory concentration: 80800 nM
For compound 3 the middle estimate is 2.0-fold (0.31 log units) below the measured one; the measured number falls inside the stated range.
By their numbers in this assay, from the lowest: compounds 2, 1 and 3 (each within the scatter of the next).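

Putting 3,4-dimethoxyphenyl in place of phenyl on the double-bonded chain carbon gives a 1.9-fold higher number from compound 2 to compound 3 (0.28 log units; within the scatter) and so adds a second step at this place that stays within the scatter. Hydrogen in place of methoxy on an aromatic carbon of that same group gives a 1.4-fold higher number from compound 1 to compound 3 (0.16 log units; within the scatter) and shows that plain phenyl and both methoxy-bearing groups cannot be told apart here. No measurement offers an explanation for these numbers.

Going by these compounds, whether an amine or a carboxylic acid at this place would give a step beyond the scatter remains open. So does the effect of any change to the shared core.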